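Fluoro for methyl on the aryl ether of compound 1

The compounds below may be only part of what the source reports. "The series", "measured", "known", "first", "only" and "open" are said of these compounds alone.

Compound 1 `Cc1ccccc1OCC1=NCCO1` is the weaker of the two measured compounds in a functional assay on the whole organism for inhibition, with Rattus norvegicus as the target, read by paw edema, with a stated time of 30 min, at a dose of 40 mg/kg by the oral route (a higher number here means a stronger effect of the compound at the dose given, a lower number a weaker effect), where compound 1 gives 29.5%. Within the data shown here, its only measured neighbour is compound 2 `Cc1ccc(OCC2=NCCO2)c(C)c1`, which in this assay gives 46.5%; the step of a number 17 percentage points higher from compound 1 to compound 2 (beyond the scatter) comes from methyl in place of hydrogen on an aromatic carbon. The unmeasured compound 3 `Fc1ccccc1OCC1=NCCO1` differs from compound 1 by fluoro in place of methyl on an aromatic carbon, on an aromatic carbon ortho to a group of 7 heavy atoms. Among the measured compounds shown here, no measured pair shows fluoro in place of methyl, so the single step seen, from adding a methyl, does not bear on this exchange directly, and nothing measured points to a step beyond the scatter. Compound 3 is therefore expected to stay close to compound 1, with an estimated step of a number 4.5 percentage points lower from compound 1 to compound 3 (within the scatter). For compound 3 the estimate in this assay is 25%, expected to lie between 8% and 45%.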

Compound 3, a percentage reported as inhibition, in the whole organism at one dose (the size of the read-out at that dose, not a potency): 30.5%
Beside the measured number, compound 3's estimate is 5.5 percentage points below it, within the range that was stated.
By their numbers in this assay, from the lowest: compounds 1 and 3 (each within the scatter of the next); then compound 2.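

In this assay, among these compounds, fluoro in place of methyl on an aromatic carbon, ortho to a group of 7 heavy atoms, gives a number 1 percentage points higher from compound 1 to compound 3 (within the scatter), so this exchange leaves no step that can be told from the scatter. The earlier step, a number 17 percentage points higher from compound 1 to compound 2 (beyond the scatter), concerned only an added methyl and said nothing about replacing the methyl at this position, where fluoro now proves to be an exchange that leaves the read-out at the same level at this single dose. Nothing measured here offers an explanation for this result.

The compounds shown leave open whether a larger or different group at this position, such as an amine, a carboxylic acid or a longer chain, would keep the read-out at this level or move it. They also leave open whether the same exchange would give a similar result on compound 2, which carries the added methyl.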